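Trimethoxyphenyl hydrazone and acetylated ring analogues, difluoro to dichloro

The source may report more compounds than this note shows. Statements on the series, on what has been measured and on what is new or still open speak of the compounds shown alone.

Measured so far:
compound 1, `COc1cc(C(=O)N/N=C/c2ccc(F)c(F)c2)cc(OC)c1OC`: 51.9%
compound 2, `COc1cc(C2=NN(C(C)=O)C(c3ccc(F)c(F)c3)O2)cc(OC)c1OC`: 21.6%

In a functional assay on BGC-823 cells (Homo sapiens) for antiproliferative activity, read by MTT assay, tested at 5 uM (a higher number here means a stronger effect of the compound at the concentration tested, a lower number a weaker effect), compound 1 gives 51.9%. Compound 2 gives 21.6% in this assay, the lower of the two numbers, a gap to compound 1 that is beyond the scatter; the two differ in more than one place, so only the two values themselves are read from this pair.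

Compound 3, `COc1cc(C2=NN(C(C)=O)C(c3ccc(Cl)c(Cl)c3)O2)cc(OC)c1OC`, is not yet measured. Its difference from compound 2 is 3,4-dichlorophenyl in place of 3,4-difluorophenyl on a saturated ring carbon. Among the measured compounds shown here, the halogen swap is the only change, with no comparable pair measured here; a step of modest size is expected, a number 6.4 percentage points higher from compound 2 to compound 3 (within the scatter), most likely within the scatter. Compound 3 is estimated at 28%, range 10% to 50%.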

Compound 3, a percentage reported as inhibition, at one concentration (the size of the read-out at that concentration, not a potency): 3.1%
The estimate for compound 3 lay 24.9 percentage points above the measured number, outside the stated range (below it).
By their numbers in this assay, from the lowest: compound 3; then compound 2; then compound 1.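

Among the compounds shown here, on the saturated ring carbon, 3,4-dichlorophenyl in place of 3,4-difluorophenyl is not a neutral exchange in this assay but gives a number 18.5 percentage points lower from compound 2 to compound 3 (beyond the scatter) as the only single-place comparison. The halogen pair on this phenyl ring alone is therefore enough to move the inhibition at this position. Nothing available accounts for the drop.

Still open, on these data alone, is how a phenyl ring bearing methoxy groups or an amine would read here. Also open, as far as these compounds go, is whether the same halogen exchange gives a similar step on the hydrazone of compound 1.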